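Removing the Methoxy from the Core of Compound 3

This account rests on a few compounds, and the source may have more. Where it says the series, first, only, none or still open, it means among the compounds named here.

Compound 1, `Cc1ccc2nc(C(=O)Nc3c(F)cc(-c4cccc(F)c4)cc3F)c(C)c(O)c2c1`, gives 0.96% in a functional assay on A-375 cells (Homo sapiens) for antiproliferative activity, read by MTT assay, with a stated time of 24 h, tested at 0.05 ug/mL; a lower number here means a weaker effect, a higher number a stronger effect of the compound at the concentration tested.
Compound 2, `Cc1c(C(=O)Nc2c(F)cc(-c3cccc(F)c3)cc2F)nc2ccc(C(F)(F)F)cc2c1O`, gives 3.47%.
Compound 3, `COc1ccc2nc(C(=O)Nc3ccc(-c4ccccc4)cc3)c(C)c(O)c2c1`, gives 1.98%.

All three measured numbers sit close to zero. Within the data shown here, the one measured step, a number 2.5 percentage points higher from compound 1 to compound 2 (within the scatter), is a change of a substituent on an aromatic carbon of the shared core, and it stays within the scatter. Compound 3 stands with compound 1 and compound 2 in a single narrow band: its value in this assay differs from that of compound 1 and from that of compound 2 by less than the scatter, so no order among the three is established.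

Compound 4, `Cc1c(C(=O)Nc2ccc(-c3ccccc3)cc2)nc2ccccc2c1O`, differs from compound 3 by hydrogen in place of methoxy on an aromatic carbon. The step from compound 1 to compound 2 bears on this only loosely, as another change of a substituent on the core, and it was small. With every measured number near zero and no step beyond the scatter, compound 4 is expected to shift by a number 0 percentage points higher from compound 3 to compound 4 (within the scatter), an amount not beyond the scatter. Compound 4 is therefore estimated at 2% in this assay, with a range from -5% to 10%.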

Compound 4, a percentage reported as inhibition, at one concentration (the size of the read-out at that concentration, not a potency): 1.05%
Compound 4: middle estimate off by 1 percentage points, on the high side; the range from low to high includes it.
By their numbers in this assay, from the lowest: compounds 1, 4, 3 and 2 (each within the scatter of the next).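

Hydrogen in place of methoxy on this aromatic carbon of the shared core gives, in this assay, a number 0.9 percentage points lower from compound 3 to compound 4 (within the scatter) and so leaves compound 4 in the same narrow band near zero as the other compounds. Among these compounds, this is the first reading at this position, and it shows that the methoxy is not needed to keep the small effect seen with compound 3, although a starting value this close to zero leaves little room for any loss to appear. The data offer no explanation for this result. What the compounds shown leave open is whether another group at this carbon, such as an amine or a carboxylic acid, would move the read-out clear of the scatter. They also leave open whether removing the methoxy would matter at a higher concentration.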